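Cyanobenzyl in place of methyl on the piperidine nitrogen

The source may hold more compounds than are shown below. What is called first, only, known or untested is meant among the compounds shown, and "the series" means these compounds.

Compound 3 `COc1ccc2nccc(C3CN(C4CCN(C)CC4)C(=O)O3)c2c1` carries a methyl group on the ring amine nitrogen. In an in vitro functional assay on RBL cells for antagonist activity at C-C chemokine receptor type 8 (Homo sapiens), read by FLIPR and calcium flux (on this read-out higher numbers stand for weaker inhibition and lower numbers for stronger inhibition), compound 3 gives only a limit, < 50200 nM, and no number. Compound 1 `COc1ccc2nccc(C3CN(C4CCN(Cc5cc6ccccc6[nH]5)C4)C(=O)O3)c2c1` likewise gives only a limit in this assay, < 50200 nM. Compound 2 `O=C1OC(c2cccc3ccccc23)CN1C1CCN(Cc2cc3ccccc3[nH]2)CC1` in this assay also gives only a limit, < 50200 nM. All three values shown thus sit at the limit of < 50200 nM in this assay, at which 3 of the 3 values shown sit, so no measured step between them can be sized, and compound 3 cannot be ranked against compound 1 or compound 2 on the numbers shown.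

Compound 4 `COc1ccc2nccc(C3CN(C4CCN(Cc5ccc(C#N)cc5)CC4)C(=O)O3)c2c1` differs from compound 3 by 4-cyanophenyl in place of hydrogen on a saturated chain carbon bound to an amine nitrogen in a ring. Going by the values given here, no measured pair shows this change. Compound 1 and compound 2 carry a different substituent on the same nitrogen, but since they also give only limits, their values say nothing about the size of such a step. The step from compound 3 to compound 4 is therefore expected to be a step that the limit leaves unreadable from compound 3 to compound 4, in the direction of stronger inhibition, with no measured support for its size. Compound 4 is expected to give 1500 nM in this assay, within a range from 150 nM to 20000 nM.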

Compound 4, half-maximal inhibitory concentration: 12600 nM
Compound 4: middle estimate off by 8.4-fold (0.92 log units), on the low side; low and high end bracket the measured number.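

Compound 4 has a number, but compound 3 has only a limit, so the step from compound 3 to compound 4 cannot be sized: the limit of < 50200 nM in this assay, at which 3 of the 4 values shown sit. The compounds shown leave open how large the effect of 4-cyanobenzyl in place of methyl on the ring amine nitrogen is in this assay.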